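This account rests on a few compounds, and the source may have more. Where it says the series, first, only, none or still open, it means among the compounds named here.

This study looks at how much of a compound cultured human bone cells can tolerate before they die. In an ADME assay on U2OS cells (Homo sapiens) for cytotoxicity, with a stated time of 96 h (a higher number here means that more compound is tolerated, a lower number that less compound is tolerated), three compounds have been measured so far. Compound 1 `CC(Oc1ccc(-c2ccccc2)cc1)C(=O)Nc1ccc(S(=O)(=O)Nc2nccs2)cc1` reaches only a limit of the assay, reported as > 200000 nM. Compound 3 `Clc1ccc(Cc2nn3c(CN4CCN(c5ccccc5)CC4)nnc3s2)cc1` likewise reaches only a limit, reported as > 200000 nM. Among the measured compounds shown here, compound 2 `CC(C)COc1ccc(CN(Cc2ccncc2)S(=O)(=O)c2ccc(F)c(F)c2)cc1` is the exception: in this assay compound 2 gives 11500 nM, the only true number among the three, so it stands clearly apart from the limit of > 200000 nM in this assay, at which 2 of the 3 values shown sit.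

Compound 4 `CC(C)COc1ccc(CN(Cc2ccncc2)S(=O)(=O)c2ccc(F)cc2F)cc1` has not yet been measured. It is built from the same atoms as compound 2, joined differently: 2,4-difluorophenyl in place of 3,4-difluorophenyl on a sulfonyl sulfur. For the measured compounds named here, no step between two measured compounds is available to show how such a rearrangement of the same atoms affects tolerated concentration. The two fluorines simply move within the same ring, and with nothing more to go on, the expected step is no change at the digits printed from compound 2 to compound 4 (within the scatter), which lies within the usual scatter of this assay. Compound 4 is therefore estimated to give 11500 nM, with an expected range from 4000 nM to 35000 nM.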

Compound 4, half-maximal cytotoxic concentration: > 200000 nM
Compound 4: no number, only a limit; the forecaster's own chance of this, stated with the estimate: 5%; middle value at least 17-fold (1.24 log units) away from the limit.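

In this assay, this first step shows that the ring on the sulfonyl sulfur is sensitive to a small rearrangement: 2,4-difluorophenyl in place of 3,4-difluorophenyl gives an at least 17-fold higher number from compound 2 to compound 4 (1.24 log units; beyond the scatter). Among the compounds shown here, the two groups have the same heavy atoms and the same aromatic ring, and only the arrangement of the two fluorines differs, a distinction the earlier compounds could not test. Compound 4 gives only a limit of the assay, so the true size of the step remains unknown, and compound 2 is now the only compound with a true number: the limit of > 200000 nM in this assay, at which 3 of the 4 values shown sit.

The compounds shown leave open which fluorine matters, a question that a 4-fluorophenyl or 2-fluorophenyl group on the sulfonyl sulfur could help to answer. They also leave open whether the arrangement in 2,4-difluorophenyl would give a similar result with other atoms in the same places, as in 2,4-dichlorophenyl, or with the same ring on a different remainder of the molecule.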